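This account rests on a few compounds, and the source may have more. Where it says the series, first, only, none or still open, it means among the compounds named here.

Three compounds have been characterised so far in an assay on CHO cells for displacement of a labelled ligand from prostaglandin D2 receptor 2 (Homo sapiens), read by scintillation counting; a lower number here means a stronger inhibitor, a higher number a weaker inhibitor. Compound 1 `COCCN(C)S(=O)(=O)c1ccc(C)c(C#Cc2cc(Cl)ccc2OCC(=O)O)c1` gives 4.1 nM in this assay. Compound 2 `CCCS(=O)(=O)c1cccc(C#Cc2cc(F)ccc2OCC(=O)O)c1` gives 65 nM. Compound 3 `O=C(O)COc1ccc(Cl)cc1C#Cc1cc(CO)ccc1F` gives 73 nM. Among these three numbers compound 2 stands near compound 3, the two values falling within the usual scatter of each other, whereas compound 1 lies clearly lower, well beyond that scatter. Among the compounds with values here, no two of the measured compounds differ in a single place, so no isolated structural step has yet been tied to a change in the inhibition constant.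

The next compound, compound 4 `CCCS(=O)(=O)c1cccc(C#Cc2cc(C#N)ccc2OCC(=O)O)c1`, has not yet been measured in this assay. Compared with compound 2 it differs as follows: cyano in place of fluoro on an aromatic carbon. Within the data shown here, with no comparable single-point step available among the measured compounds, the direction of the effect cannot be read from the data; a modest step is expected, and its size is estimated as a 1.6-fold lower number from compound 2 to compound 4 (0.21 log units; within the scatter). On that basis the inhibition constant of compound 4 in this assay is expected to be about 40 nM, most likely between 12 nM and 130 nM.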

Compound 4, inhibition constant: 21 nM
Beside the measured number, compound 4's estimate is 1.9-fold (0.28 log units) above it; the measured number falls inside the stated range.
By their numbers in this assay, from the lowest: compound 1; then compound 4; then compounds 2 and 3 (each within the scatter of the next).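

Within the data shown here, this is the first step that changes only one place, and it shows that the group para to the carboxymethoxy group matters in this assay: cyano in place of fluoro gives a 3.1-fold lower number from compound 2 to compound 4 (0.49 log units; beyond the scatter). The step is modest but lies beyond the scatter, so this position does not merely tolerate change, and a lower number is reached with the larger group. This holds for one pair only, with the propylsulfonyl-bearing core of compound 2 kept constant.

As far as these compounds go, whether a trifluoromethyl group or a carboxamide in this place would extend the trend remains open, as does whether the same change would carry over to the core of compound 1. No measurement at hand explains why the cyano compound gives the lower number.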